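A few compounds are considered here, and "the series" means these few. Any claim that something is new, unique, unknown or untested is made for them only; others in the source may bear on it.

Working notes on the series. In an assay on brain for binding affinity to Neuronal acetylcholine receptor; alpha4/beta2 (Rattus norvegicus), read by radioligand binding (on this read-out lower numbers stand for stronger inhibition and higher numbers for weaker inhibition), compound 1 `Fc1ccc(OC[C@@H]2CCN2)cn1` gives 0.057 nM and compound 3 `Nc1cncc(OC[C@@H]2CCN2)c1` gives 0.082 nM; the two lie within the scatter of each other. Compound 2 `CCc1ccc(OC[C@@H]2CCN2)cn1` gives 19 nM in this assay. Among the three numbers compound 3 stands second highest, with compound 1 nearest and compound 2 furthest away.

For the measured compounds named here, the only single-point step measured is a 330-fold higher number from compound 1 to compound 2 (2.52 log units; beyond the scatter). It bears on the move to compound 4 `c1ccc(-c2cncc(OC[C@@H]3CCN3)c2)cc1`, which carries phenyl in place of amino on an aromatic carbon. Phenyl, like ethyl, is a carbon-only group without hydrogen-bond donor or acceptor, and no aryl substituent has been measured in the series, so the parallel is loose.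

Because a 330-fold higher number from compound 1 to compound 2 (2.52 log units; beyond the scatter) already moved the number far beyond the scatter, a shift of broadly comparable size in the same direction is expected for compound 4, though somewhat tempered. Compound 4 is therefore expected to give about 3 nM in this assay, within a range from 0.3 nM to 30 nM. The estimated step is a 37-fold higher number from compound 3 to compound 4 (1.56 log units; beyond the scatter).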

Compound 4, inhibition constant: 0.046 nM
Compound 4: the middle estimate sits 65-fold (1.81 log units) above what was measured; the whole stated range lies above it.
By their numbers in this assay, from the lowest: compounds 4, 1 and 3 (each within the scatter of the next); then compound 2.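

In this assay, the aromatic carbon two atoms from the ring nitrogen takes phenyl in place of amino with a 1.8-fold lower number from compound 3 to compound 4 (0.25 log units; within the scatter). At this position, then, a much larger, carbon-only group with 0 hydrogen-bond donors and 0 hydrogen-bond acceptors leaves the number where amino had it, and the large step of a 330-fold higher number from compound 1 to compound 2 (2.52 log units; beyond the scatter), which belongs to another pair and another change, does not carry over. Nothing available explains why the two steps differ in size.

On these data alone, it remains open whether a carboxylic acid, a dimethylamino group or a longer alkyl chain on this carbon would also stay within the scatter of compound 3. As far as these compounds go, it is equally open whether phenyl in place of the fluoro of compound 1 would behave as ethyl does there.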